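The compounds below may be only part of what the source reports. "The series", "measured", "known", "first", "only" and "open" are said of these compounds alone.

Working notes on the series. Going by the values given here, compound 1 `CCCCc1nc2ccccc2n1Cc1ccc(C(=O)O)cc1` is the reference here; in an in vivo functional assay on the whole organism for antagonist activity at Type-2 angiotensin II receptor (Rattus norvegicus) (a higher number here means that more compound is needed for the effect, a lower number that less compound is needed), compound 1 gives 12.6 mg/kg, the only number in the set. Compound 2 `CCCCCCc1nc2ccccc2n1Cc1ccc(C(=O)O)cc1` carries a hexyl chain in place of the butyl. In this assay compound 2 reaches only a limit, > 20 mg/kg. Among the compounds with values here, the one measured step, an at least 1.5-fold higher number from compound 1 to compound 2 (0.20 log units; that floor lies within the scatter), is therefore read against the limit of > 20 mg/kg in this assay, at which 1 of the 2 values shown sits, and cannot be sized beyond its floor.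

Compound 3 `CCCCc1nc2cc(F)ccc2n1Cc1ccc(C(=O)O)cc1` differs from compound 1 by fluoro in place of hydrogen on an aromatic carbon, the chain left untouched. Within the data shown here, no measured step touches the fused ring of the core, so the hexyl step gives no guide to this change; nothing recorded points in either direction. For compound 3 the expected result in this assay is a step of no change at the digits printed from compound 1 to compound 3 (within the scatter), that is, none beyond the scatter. Compound 3 is estimated at 12.6 mg/kg, within 5 mg/kg to 30 mg/kg.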

Compound 3, dose for half-maximal effect: 9.1 mg/kg
Beside the measured number, compound 3's estimate is 1.4-fold (0.14 log units) above it; measured number inside the range.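

In this assay, going by these compounds alone, fluoro in place of hydrogen on an aromatic carbon gives the first reading on the fused system of the shared core, where the earlier compounds changed only the chain: a 1.4-fold lower number from compound 1 to compound 3 (0.14 log units; within the scatter). This position, meta to a fused ring and para to a fused ring, therefore takes fluoro without a change beyond the scatter, at least for the butyl chain of compound 1 and compound 3. Compound 2 remains a limit, so the hexyl step has no full size to set against the fluoro step: the limit of > 20 mg/kg in this assay, at which 1 of the 3 values shown sits.

From the compounds shown here alone, whether chloro, methoxy or an amine at this position would move the number beyond the scatter remains open. Also open, going by these compounds, is whether fluoro on another carbon of this ring, or a propyl chain in place of the butyl, would do so.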